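A few compounds are considered here, and "the series" means these few. Any claim that something is new, unique, unknown or untested is made for them only; others in the source may bear on it.

Measured compounds:
compound 1 `Nc1noc2ccc(-n3nc(C(F)(F)F)c4c3C(=O)N(c3ccc(-c5ccccc5CN5CCCC5)cc3F)CC4)cc12`: 4.9 h
compound 2 `CN(C)Cc1ccccc1-c1ccc(N2CCc3c(C(F)(F)F)nn(-c4ccc5onc(N)c5c4)c3C2=O)c(F)c1`: 6.4 h
compound 3 `Cc1nn(-c2ccc3onc(N)c3c2)c2c1CCN(c1ccc(-c3ccccc3CN3CCCC3)cc1)C2=O`: 1.7 h

In an in vivo ADME assay on the whole organism for metabolic stability, with Canis familiaris (Canis lupus familiaris) as the target (on this read-out lower numbers stand for a shorter-lived compound and higher numbers for a longer-lived compound), compound 1 gives 4.9 h. That places it within the scatter of compound 2 and beyond the scatter above compound 3.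

Compound 4 `Nc1noc2ccc(-n3nc(C(F)(F)F)c4c3C(=O)N(c3ccc(-c5ccccc5CN5CCCC5)cc3)CC4)cc12` has not yet been measured. It differs from compound 1 by one change: hydrogen in place of fluoro on an aromatic carbon. Hydrogen stands in place of fluoro on an aromatic carbon of a six-membered aromatic ring of carbon only, ortho to a large group.

Among the measured compounds shown here, no measured step isolates this change. For the measured compounds named here, the only single-place step, a 1.3-fold higher number from compound 1 to compound 2 (0.12 log units; within the scatter), concerns the amine on the saturated chain carbon and stays within the scatter, so it says little about the fluoro. Going by the values given here, compound 3 gives the lowest number, 1.7 h, but no single-place step links it to compound 1, so it serves only as a caution towards lower numbers.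

In this assay, a step beyond the scatter is therefore not expected, though a slight downward lean seems reasonable. The estimate for compound 4 is 4 h, with an expected range of 2.1 h to 7 h. This estimate means an expected 1.2-fold lower number from compound 1 to compound 4 (0.09 log units; within the scatter).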

Compound 4, half-life: 5.3 h
Compound 4: the middle estimate sits 1.3-fold (0.12 log units) below what was measured; measured number inside the range.
By their numbers in this assay, from the lowest: compound 3; then compounds 1, 4 and 2 (each within the scatter of the next).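

Among the compounds shown here, for the read-out of this assay the fluoro on the aromatic carbon ortho to a large group can give way to hydrogen without a step beyond the scatter (a 1.1-fold higher number from compound 1 to compound 4 (0.03 log units; within the scatter)), which is the first direct reading of this position. For the compounds shown here, compound 4 also ties compound 3 to the others by a single change for the first time, and that step, with trifluoromethyl in place of methyl on an aromatic carbon (a 3.1-fold higher number from compound 3 to compound 4 (0.49 log units; beyond the scatter)), is the only single-place step so far that goes beyond the scatter, whereas the fluoro and amine steps both stay within it. No measurement available here accounts for either step.

From the compounds shown here alone, it remains open whether other groups on the fluoro position, such as chloro or methoxy, would also stay within the scatter, and whether hydrogen in place of fluoro would read the same with dimethylamino rather than pyrrolidin-1-yl on the saturated chain carbon. Trifluoromethyl is set against methyl alone, so the compounds shown say nothing about how an ethyl group or a nitrile would read on that aromatic carbon.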